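Swapping amino for methoxy on a cytotoxic chalcone-like scaffold

The compounds below may be only part of what the source reports. "The series", "measured", "known", "first", "only" and "open" are said of these compounds alone.

Measured so far:
- compound 1, `COc1cc(-c2cc(/C=C/C(=O)c3ccc(N)cc3)[nH]n2)cc(OC)c1OC`: -39%
- compound 2, `COc1ccc(-c2cc(/C=C/C(=O)c3ccc(OC)c(OC)c3)[nH]n2)cc1`: -90%
- compound 3, `COc1ccc(-c2cc(/C=C/C(=O)c3ccc(N)cc3)[nH]n2)cc1OC`: -48%

All three were tested in a functional assay on PC-3 cells (Homo sapiens) for cytotoxicity, read by sulforhodamine B assay, with a stated time of 48 h, tested at 100 uM; a lower number here means a stronger effect, a higher number a weaker effect of the compound at the concentration tested. Compound 1 gives the highest number of the three, and so the weakest effect at the tested concentration. Compound 3 sits closest to it: the step of a number 9 percentage points lower from compound 1 to compound 3 (within the scatter) lies within the scatter. Compound 2 sits furthest away, with a much lower number and so a much stronger effect, but it differs from compound 1 in more than one place, so its value alone cannot be tied to any single change.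

Compound 4, `COc1ccc(C(=O)/C=C/c2cc(-c3cc(OC)c(OC)c(OC)c3)n[nH]2)cc1`, has not yet been measured. It differs from compound 1 by methoxy in place of amino on an aromatic carbon. Going by the values given here, no measured step covers this change: the only measured step concerns a methoxy group elsewhere and is within the scatter. Compounds 1 and 3 both carry an amino group at that place and give the two higher numbers. Compound 2 carries a methoxy group at that place and gives a much lower number than either. For compound 4 a shift toward a lower number is therefore expected, a number 21 percentage points lower from compound 1 to compound 4 (beyond the scatter), though with wide uncertainty. The estimate for compound 4 is -60%, expected to fall between -95% and -25%.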

Compound 4, a percentage reported as activity, at one concentration (the size of the read-out at that concentration, not a potency): 1%
Estimate against measurement, compound 4: 61 percentage points below; measured number above the stated range.
By their numbers in this assay, from the lowest: compound 2; then compounds 3 and 1 (each within the scatter of the next); then compound 4.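

In this assay, going by these compounds alone, replacing 4-aminophenyl with 4-methoxyphenyl gives a number 40 percentage points higher from compound 1 to compound 4 (beyond the scatter), the first measured change at this place on the ring. Unlike the methoxy change elsewhere, a number 9 percentage points lower from compound 1 to compound 3 (within the scatter), this one is clearly larger than the usual scatter, so this position matters for the read-out, and on this core the amino compound has the stronger effect at the tested concentration. Nothing available here explains why the swap has this effect.

The compounds shown leave open whether the same swap would act alike on the core of compound 3, since this step comes from a single pair. They also leave open how other groups at this place would compare, such as a hydroxyl, a dimethylamino group or an acetamide.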